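A dihydroxyphenyl cap on the shared core of compound 1

This account rests on a few compounds, and the source may have more. Where it says the series, first, only, none or still open, it means among the compounds named here.

Measured so far:
compound 1 `N#Cc1ccc(/C=N/NC(=O)Nc2cc3c(Nc4ccc(F)c(Cl)c4)ncnc3cc2O[C@H]2CCOC2)cc1` — 28100 nM
compound 2 `COc1cc(/C=N/NC(=O)Nc2cc3c(Nc4ccc(F)c(Cl)c4)ncnc3cc2O[C@H]2CCOC2)cc(OC)c1OC` — 29600 nM
compound 3 `O=C(N/N=C/c1ccc(O)c(Br)c1)Nc1cc2c(Nc3ccc(F)c(Cl)c3)ncnc2cc1O[C@H]1CCOC1` — 5230 nM

All three were tested in a functional assay on PC-3 cells (Homo sapiens) for cytotoxicity, read by MTT assay, with a stated time of 72 h; a higher number here means a weaker inhibitor, a lower number a stronger inhibitor. Compound 1 stands second highest of the three numbers. Its nearest neighbour is compound 2, with a 1.1-fold higher number from compound 1 to compound 2 (0.02 log units; within the scatter), a difference that stays within the scatter. Its furthest neighbour is compound 3, with a 5.4-fold lower number from compound 1 to compound 3 (0.73 log units; beyond the scatter), a modest step beyond the scatter. Between compound 2 and compound 3 the step is a 5.7-fold lower number from compound 2 to compound 3 (0.75 log units; beyond the scatter).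

Compound 4 `O=C(N/N=C/c1ccc(O)cc1O)Nc1cc2c(Nc3ccc(F)c(Cl)c3)ncnc2cc1O[C@H]1CCOC1` has not yet been measured. It differs from compound 1 in one place: 2,4-dihydroxyphenyl in place of 4-cyanophenyl on a carbon with a double bond to nitrogen.

The step from compound 1 to compound 3 bears on this change because a 5.4-fold lower number from compound 1 to compound 3 (0.73 log units; beyond the scatter) likewise brought in a phenyl carrying a hydroxyl in place of the 4-cyanophenyl. The step to compound 2, which brought in methoxy groups only, stayed within the scatter. Compound 4 is therefore expected to give a lower number than compound 1, by about a 3.1-fold lower number from compound 1 to compound 4 (0.49 log units; beyond the scatter). The estimate for compound 4 in this assay is 9000 nM, in a range from 3000 nM to 25000 nM.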

Compound 4, half-maximal inhibitory concentration: 7540 nM
The estimate for compound 4 lay 1.2-fold (0.08 log units) above the measured number, and the stated range covers the measured number.
By their numbers in this assay, from the lowest: compounds 3 and 4 (each within the scatter of the next); then compounds 1 and 2 (each within the scatter of the next).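

With a second hydroxyl-bearing cap, the result in this assay no longer rests on compound 3 alone: the 2,4-dihydroxyphenyl group also separates from the 4-cyanophenyl group (a 3.7-fold lower number from compound 1 to compound 4 (0.57 log units; beyond the scatter)) and from the 3,4,5-trimethoxyphenyl group (a 3.9-fold lower number from compound 2 to compound 4 (0.59 log units; beyond the scatter)). Bromine is therefore not required for a step of this size at this position, and the two hydroxyl-bearing caps cannot be told apart (a 1.4-fold higher number from compound 3 to compound 4 (0.16 log units; within the scatter)), with neither of the listed compounds going against this pattern. No supporting measurement is available to explain why these caps differ from the other two.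

The compounds shown leave open whether a phenyl carrying a single hydroxyl and no bromine would behave like compound 4. They also leave open how an amine or a carboxylic acid on the phenyl would compare with the hydroxyl.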